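Cyano for methyl on the anilide of compound 3

The source may report more compounds than this note shows. Statements on the series, on what has been measured and on what is new or still open speak of the compounds shown alone.

Measured compounds in a functional assay on B16-F10 cells (Mus musculus) for cytotoxicity, read by MTT assay, with a stated time of 48 h; on this read-out lower numbers stand for stronger inhibition and higher numbers for weaker inhibition:
compound 1, `COc1ccc(CN(C(=O)Nc2ccc(C#N)cc2)n2cnnc2)cc1OC`: > 50000 nM, which is a limit of the assay, not a number.
compound 2, `CCc1ccc(NC(=O)N(Cc2cc(OC)c(OC)c(OC)c2)n2cnnc2)cc1`: 24700 nM.
compound 3, `COc1cc(CN(C(=O)Nc2ccc(C)cc2)n2cnnc2)cc(OC)c1OC`: 46800 nM.

For the measured compounds named here, compound 3 holds the highest of the two numbers in this assay; its nearest neighbour is compound 2, and the only measured step, a 1.9-fold higher number from compound 2 to compound 3 (0.28 log units; within the scatter), stays within the scatter. The third value is the limit of compound 1, (the limit of > 50000 nM in this assay, at which 1 of the 3 values shown sits).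

Compound 4, `COc1cc(CN(C(=O)Nc2ccc(C#N)cc2)n2cnnc2)cc(OC)c1OC`, is not yet measured. It differs from compound 3 by cyano in place of methyl on an aromatic carbon. Going by the values given here, no measured step bears directly on this change: the single step in this assay, from compound 2 to compound 3, concerns a methyl on the anilide and lies within the scatter. Compound 1 carries the same cyano group on a different core and gave only a limit.

Given that compound 3 already sits near the top of the measured range and that compound 1 reached only a limit, no step beyond the scatter is expected for compound 4, a 1.3-fold higher number from compound 3 to compound 4 (0.11 log units; within the scatter), with a fair chance that the assay reports only a limit. The expected value for compound 4 is 60000 nM, within 30000 nM to 120000 nM.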

Compound 4, half-maximal inhibitory concentration: 21000 nM
Compound 4: middle estimate off by 2.9-fold (0.46 log units), on the high side; the measured number lies below the stated range.
By their numbers in this assay, from the lowest: compounds 4, 2 and 3 (each within the scatter of the next, the first and the last beyond it). At a limit, above all of these: compound 1.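

In this assay the change from 4-methylphenyl to 4-cyanophenyl on the shared core gives a step beyond the scatter (a 2.2-fold lower number from compound 3 to compound 4 (0.35 log units; beyond the scatter)), which the earlier step between methyl and ethyl at this position did not give. Cyano and ethyl at the same position cannot be told apart (a 1.2-fold lower number from compound 2 to compound 4 (0.07 log units; within the scatter)), so the three groups form no clear order: only the methyl and cyano pair separates, and only modestly. With methoxy in place of hydrogen on an aromatic carbon, a second step appears (an at least 2.3-fold lower number from compound 1 to compound 4 (0.37 log units; beyond the scatter)), but it rests on compound 1, whose value is a limit and not a number: the limit of > 50000 nM in this assay, at which 1 of the 4 values shown sits.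

The compounds shown leave open whether an amine, a carboxylic acid or a longer chain on this aromatic carbon would move the number further in this assay than cyano does. Also open, going by these compounds, is whether the step from methyl to cyano carries over to the core of compound 1.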